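Removing the nitrile from compound 3

This account rests on a few compounds, and the source may have more. Where it says the series, first, only, none or still open, it means among the compounds named here.

Compound 1 `CCCC(Oc1ccc(-n2cc(C(=O)N(C)C)cn2)cc1)c1ccc(C(=O)NCCC(=O)O)cc1` gives 0.5
Compound 2 `CCCC(Oc1ccc(-n2cc(C(F)(F)F)c(C)n2)cc1)c1ccc(C(=O)NCCC(=O)O)cc1` gives 2.8
Compound 3 `CCCC(Oc1ccc(-n2cc(C#N)cn2)cc1)c1ccc(C(=O)NCCC(=O)O)cc1` gives 1.2

These numbers come from a physicochemical assay for lipophilicity, using the shake flask method, at pH 7.4 (a higher number here means a more lipophilic compound, a lower number a more polar compound), and place compound 3 in the middle of the three, above compound 1 and below compound 2. Compound 4 `CCCC(Oc1ccc(-n2cccn2)cc1)c1ccc(C(=O)NCCC(=O)O)cc1` has not been measured yet. It differs from compound 3 in one place, with hydrogen in place of cyano on an aromatic carbon so that the nitrile is simply gone.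

Among the measured compounds shown here, two measured steps touch this spot. Cyano in place of dimethylcarbamoyl gave a modest change (a number 0.70 log units higher from compound 1 to compound 3 (beyond the scatter)), while 4-cyano-1H-pyrazol-1-yl in place of 3-methyl-4-(trifluoromethyl)-1H-pyrazol-1-yl gave a large one (a number 1.60 log units lower from compound 2 to compound 3 (beyond the scatter)). Neither puts bare hydrogen on the ring, so neither answers the question directly. Compound 3, at 1.2 in this assay, carries a smaller group than compound 1 and stands higher, so a further rise is expected. Compound 2 (2.8) warns against relying on size alone, since it stands highest with two groups on that ring. The expected change is modest and upward (a number 0.40 log units higher from compound 3 to compound 4 (beyond the scatter)). For compound 4 the estimated value is 1.6 with an expected range from 1.2 to 2.1 in this measurement.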

Compound 4, distribution coefficient: 1.7
Beside the measured number, compound 4's estimate is 0.10 log units below it; low and high end bracket the measured number.
By their numbers in this assay, from the lowest: compound 1; then compound 3; then compound 4; then compound 2.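

In this assay, among the compounds shown here, compound 4 gives the first reading for the pyrazole ring with only hydrogen on this aromatic carbon, and it stands above both compounds that carry a polar-looking nitrogen group there: a number 0.50 log units higher from compound 3 to compound 4 (beyond the scatter), and a number 1.20 log units higher from compound 1 to compound 4 (beyond the scatter). Taking a group off this position does not always move the number the same way, however, and compound 2 goes against any rule that the bare ring stands highest: a number 1.10 log units lower from compound 2 to compound 4 (beyond the scatter). The bare ring therefore serves as a reference point, with the cyano and dimethylcarbamoyl compounds on one side of it and the methyl and trifluoromethyl compound on the other, but nothing shown accounts for why the groups fall on these sides.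

Going by these compounds, the separate shares of the methyl and the trifluoromethyl remain open, as the two groups appear only together in compound 2. Where an amine or a carboxylic acid on this same aromatic carbon would fall relative to compound 4 also remains open.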